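A few compounds are considered here, and "the series" means these few. Any claim that something is new, unique, unknown or untested is made for them only; others in the source may bear on it.

Measured in a functional assay on MDA-MB-231 cells (Homo sapiens) for cytotoxicity, read by MTT assay, with a stated time of 72 h; on this read-out higher numbers stand for weaker inhibition and lower numbers for stronger inhibition:
- compound 1 `CC1CCN(Cc2ccc3nc(NC(=O)N/N=C/c4c[nH]c5ccccc45)sc3c2)CC1`: 2460 nM
- compound 2 `CCN(CC)Cc1ccc2nc(NC(=O)N/N=C/c3cn(Cc4ccc(C)cc4)c4ccccc34)sc2c1`: 2010 nM
- compound 3 `CN(C)Cc1ccc2nc(NC(=O)N/N=C/c3c[nH]c4ccccc34)sc2c1`: 1190 nM

Not yet measured: compound 4 `CCN(CC)Cc1ccc2nc(NC(=O)N/N=C/c3c[nH]c4ccccc34)sc2c1`.

Compound 3, at 1190 nM, shares the low end of these numbers with compound 2, at 2010 nM, and the two lie within the scatter of each other. Compound 1 stands apart from compound 3 by a step beyond the scatter.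

The change under consideration is diethylamino in place of dimethylamino on a saturated chain carbon bound to an aromatic carbon.

Within the data shown here, one measured step touches this place: a 2.1-fold lower number from compound 1 to compound 3 (0.32 log units; beyond the scatter), with dimethylamino in place of 4-methylpiperidin-1-yl. Leaving dimethylamino for another amino group may therefore raise the number in this assay, but this single modest step is thin support. Compound 4 would share diethylamino with compound 2 but differs from it elsewhere as well, so compound 2, at 2010 nM, serves only as a rough guide.

The expected change is small and upward, not beyond the scatter: a 1.4-fold higher number from compound 3 to compound 4 (0.15 log units; within the scatter) is the estimated step. For compound 4 the estimated value is 1700 nM, within an expected range of 950 nM to 3000 nM.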

Compound 4, half-maximal inhibitory concentration: 1900 nM
Estimate against measurement, compound 4: 1.1-fold (0.05 log units) below, within the range that was stated.
By their numbers in this assay, from the lowest: compounds 3, 4, 2 and 1 (each within the scatter of the next, the first and the last beyond it).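

Read in this assay, diethylamino in place of dimethylamino on a saturated chain carbon bound to an aromatic carbon gives a step that stays inside the scatter (a 1.6-fold higher number from compound 3 to compound 4 (0.20 log units; within the scatter)), and diethylamino in place of 4-methylpiperidin-1-yl does the same (a 1.3-fold lower number from compound 1 to compound 4 (0.11 log units; within the scatter)), so of the two amino groups compared with 4-methylpiperidin-1-yl, only dimethylamino shows a step beyond the scatter (a 2.1-fold lower number from compound 1 to compound 3 (0.32 log units; beyond the scatter)), and that step is itself modest. Among these compounds, compound 4 also gives the first single-place reading on the aromatic nitrogen, where hydrogen in place of 4-methylbenzyl leaves the number within the scatter (a 1.1-fold lower number from compound 2 to compound 4 (0.02 log units; within the scatter)), so the presence of that large group shows no measurable cost or gain here. No measurement at hand explains any of these steps.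

As far as these compounds go, whether a pyrrolidin-1-yl or morpholin-4-yl group on the same saturated chain carbon would separate from dimethylamino remains open, as does the effect of a longer chain such as di-n-propylamino. From the compounds shown here alone, on the aromatic nitrogen, it is equally open whether a plain benzyl or a methyl would stay within the scatter of hydrogen.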